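Carboxy to methylcarbamoyl on the pyridine-bearing sulfonamide series

This account rests on a few compounds, and the source may have more. Where it says the series, first, only, none or still open, it means among the compounds named here.

Measured compounds:
compound 1, `COc1ccc(Cl)cc1S(=O)(=O)Nc1cncc(-c2ccc(Cl)cc2)c1`; in an assay on isolated protein for inhibition of alkaline phosphatase, tissue-nonspecific isozyme (Homo sapiens) (a higher number here means a weaker inhibitor, a lower number a stronger inhibitor), compound 1 gives "not determined" (no result reported).
compound 2, `COc1ccc(Cl)cc1S(=O)(=O)Nc1cncc(C(=O)N2CCN(C)CC2)c1`; in this assay compound 2 gives "not determined" (no result reported).
compound 3, `COc1ccc(Cl)cc1S(=O)(=O)Nc1cncc(C(=O)O)c1`; in this assay compound 3 gives > 20000 nM.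

Within the data shown here, compound 3 is the only member with any reading in this assay, and that reading is a limit of the assay rather than a number. Among the measured compounds shown here, compound 1 and compound 2 return no result at all, so no step between measured compounds can be computed, and compound 3 stands alone at the limit of > 20000 nM in this assay, at which 1 of the 3 values shown sits.

Compound 4, `CNC(=O)c1cncc(NS(=O)(=O)c2cc(Cl)ccc2OC)c1`, is the next entry to be measured in this assay. It differs from compound 3 in one place: methylamino in place of hydroxy on a carbonyl carbon. The carboxy group of compound 3 is thus exchanged for methylcarbamoyl, with the rest of the molecule unchanged.

For the measured compounds named here, with no measured step to lean on, the step from compound 3 to compound 4 is expected to be small, within the usual scatter in either direction, and it is estimated as a step that the limit leaves unreadable from compound 3 to compound 4. Compound 4 is therefore expected to fall near 25000 nM, within a range of 8000 nM to 80000 nM, and the assay may well again report only a limit for compound 4.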

Compound 4, half-maximal inhibitory concentration: > 20000 nM
Compound 4: only a limit was reported; the forecaster's own chance of this, stated with the estimate: 60%; the middle value lies beyond the limit too.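

In this assay compound 3 and compound 4 each rest on a limit of the assay rather than a number, so no step between them can be read: the limit of > 20000 nM in this assay, at which 2 of the 4 values shown sit.

The compounds shown leave open whether any group on this carbonyl carbon gives a measurable inhibition in this assay.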